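The compounds below may be only part of what the source reports. "The series", "measured", "known", "first", "only" and "open" are said of these compounds alone.

In a functional assay on SK-OV-3 cells (Homo sapiens) for antiproliferative activity, read by MTT assay, with a stated time of 72 h (on this read-out lower numbers stand for stronger inhibition and higher numbers for weaker inhibition), compound 1 `CC(C)c1cccc(NC(=O)CCc2cccc3c2B(O)OC3)c1` gives 510 nM and compound 2 `O=C(CCc1cccc2c1B(O)OC2)Nc1cccc(-c2cccc(F)c2)c1` gives 480 nM, so compound 2 stands level with compound 1, within the scatter. Compound 3 `O=C(CCc1cccc2c1B(O)OC2)Nc1cccc(-c2ccc(F)cc2)c1` carries 4-fluorophenyl in place of 3-fluorophenyl on an aromatic carbon. Among the compounds with values here, only one measured step bears on this change, and it swapped a whole group, 3-fluorophenyl in place of isopropyl, giving just a 1.1-fold lower number from compound 1 to compound 2 (0.03 log units; within the scatter). Within the data shown here, no measured step shows what moving the fluorine does, so no shift beyond the scatter is expected, and the expected step is no change at the digits printed from compound 2 to compound 3 (within the scatter). For compound 3 the estimate is 480 nM, with a range of 230 nM to 1000 nM.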

Compound 3, half-maximal inhibitory concentration: 93 nM
Beside the measured number, compound 3's estimate is 5.2-fold (0.71 log units) above it; the measured number lies below the stated range.
By their numbers in this assay, from the lowest: compound 3; then compounds 2 and 1 (each within the scatter of the next).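

In this assay the place of the fluorine matters: 4-fluorophenyl in place of 3-fluorophenyl gives a 5.2-fold lower number from compound 2 to compound 3 (0.71 log units; beyond the scatter) even though the two groups have the same atoms. Against the isopropyl compound, 4-fluorophenyl gives a 5.5-fold lower number from compound 1 to compound 3 (0.74 log units; beyond the scatter) as well, so this position does respond to a change of group, which the earlier pair could not show. Nothing available explains why moving the fluorine has this effect. As far as these compounds go, whether a plain phenyl, 4-chlorophenyl or 4-aminophenyl would match compound 3 remains open.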